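A few compounds are considered here, and "the series" means these few. Any claim that something is new, unique, unknown or untested is made for them only; others in the source may bear on it.

Compound 1 `CS(=O)(=O)c1ccc(-c2oc3ccccc3c(=S)c2-c2ccc(F)cc2)cc1` was examined in an assay on isolated protein for inhibition of prostaglandin G/H synthase 1 (Mus musculus), tested at 10 ug/mL (on this read-out lower numbers stand for less inhibition and higher numbers for more inhibition at the one concentration tested (going by the name of the read-out)), where compound 1 gives < 5%, which is a limit of the assay rather than a number. Compound 2 `CS(=O)(=O)c1ccc(-c2oc3ccccc3c(=O)c2-c2cccc(Cl)c2)cc1` gives < 5% in this assay, again a limit. Both compounds fall under (the limit of < 5% in this assay, at which 2 of the 2 values shown sit). Compound 3 `COc1ccc(-c2c(-c3ccc(S(C)(=O)=O)cc3)oc3ccccc3c2=S)cc1` is the untested partner of compound 1, differing by methoxy in place of fluoro on an aromatic carbon. With both measured compounds at the limit, no step beyond the scatter is expected, and the estimated step is a step that the limit leaves unreadable from compound 1 to compound 3. Compound 3 is therefore expected to show about 3%, within 0% to 12%.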

Compound 3, a percentage reported as inhibition, at one concentration (the size of the read-out at that concentration, not a potency): < 5%
Compound 3 was reported as a limit; the forecaster's own chance of this, stated with the estimate: 80%; the middle value lies beyond the limit too.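

In this assay compound 3 gives < 5% as a limit of the assay, so no step can be read between compound 1 and compound 3. The compounds shown leave open whether methoxy in place of fluoro changes inhibition at all, since every value sits at the same limit: the limit of < 5% in this assay, at which 3 of the 3 values shown sit.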